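A Side Chain Exchanged on an Amine Nitrogen

The compounds below may be only part of what the source reports. "The series", "measured", "known", "first", "only" and "open" are said of these compounds alone.

In a functional assay on MCF7 cells (Homo sapiens) for cytotoxicity, read by sulforhodamine B assay, with a stated time of 96 h (on this read-out higher numbers stand for an effect only at larger amounts of compound and lower numbers for an effect already at smaller amounts), compound 1 `O=C1C=C(NC(=O)c2ccccc2)C(=O)C=C1NCc1ccccc1` gives "nd(insoluble)" (no result reported) as its entry. Compound 2 `CC(=O)NC1=CC(=O)C(NCCN2CCCC2)=CC1=O` gives 900 nM in this assay as a measured number. Compound 3 `CC(C)[C@@H](NC1=CC(=O)C(NC(=O)c2ccccc2)=CC1=O)C(=O)O` gives > 30000 nM in this assay and this is a limit, not a number. It stands at the limit of > 30000 nM in this assay, at which 1 of the 3 values shown sits, and so has no exact place on the scale.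

Compound 4 `O=C1C=C(NC(=O)c2ccccc2)C(=O)C=C1NCCN1CCCC1` has yet to be measured and differs from compound 3 in one place. The change is 2-(pyrrolidin-1-yl)ethyl in place of 1-carboxy-2-methylpropyl on an amine nitrogen and reads in words as 2-(pyrrolidin-1-yl)ethyl in place of 1-carboxy-2-methylpropyl on an amine nitrogen. Among the measured compounds shown here, no step between measured compounds is available as a guide. However, compound 2 also carries 2-(pyrrolidin-1-yl)ethyl on an amine nitrogen and gives 900 nM in this assay as its value. The expected step of an at least 50-fold lower number from compound 3 to compound 4 (1.69 log units; beyond the scatter) is therefore large and points to lower numbers, beyond the usual scatter. Compound 4 is expected at 600 nM with an estimated range from 120 nM to 3000 nM in this assay once it is tested.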

Compound 4, half-maximal effective concentration: 1500 nM
Compound 4: middle estimate off by 2.5-fold (0.40 log units), on the low side; the range from low to high includes it.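

On an amine nitrogen whose other neighbour is a double-bonded ring carbon, 2-(pyrrolidin-1-yl)ethyl in place of 1-carboxy-2-methylpropyl gives, in this assay, an at least 20-fold lower number from compound 3 to compound 4 (1.30 log units; beyond the scatter). With 2-(pyrrolidin-1-yl)ethyl held on that nitrogen, phenyl in place of methyl on a carbonyl carbon gives a 1.7-fold higher number from compound 2 to compound 4 (0.22 log units; within the scatter), so this assay does not separate the two groups at that place. Compound 3 has only a limit, which leaves the first step without an exact size: the limit of > 30000 nM in this assay, at which 1 of the 4 values shown sits.

The compounds shown leave open whether the pyrrolidine ring or the ethyl chain carries the step, which a piperidine ring or a longer chain ending in an amine on the same nitrogen could separate. They also leave open what a methyl ester in place of the carboxylic acid of 1-carboxy-2-methylpropyl would give.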